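From 3-methylbenzyl to 4-methoxybenzyl

This account rests on a few compounds, and the source may have more. Where it says the series, first, only, none or still open, it means among the compounds named here.

Measured so far in a functional assay on HepG2 cells (Homo sapiens) for inhibition, read by MTT assay, with a stated time of 72 h (a higher number here means a weaker inhibitor, a lower number a stronger inhibitor), for this small set:
compound 1 `Cc1cc(C)cc(CN2CCc3ncn(COCc4ccccc4)c3/C(=C/c3ccccc3)C2=O)c1` gives 40900 nM
compound 2 `Cc1cccc(CN2CCc3ncn(COCc4ccccc4)c3/C(=C/c3ccccc3)C2=O)c1` gives 34300 nM

Compound 1 and compound 2 cannot be told apart within the scatter, and compound 2 stands at 34300 nM in this pair. The next compound is compound 3 `COc1ccc(CN2CCc3ncn(COCc4ccccc4)c3/C(=C/c3ccccc3)C2=O)cc1` with 4-methoxyphenyl in place of 3-methylphenyl on a saturated chain carbon bound to an amide-type nitrogen in a ring as the whole change. Within the data shown here, the one measured step, a 1.2-fold lower number from compound 1 to compound 2 (0.08 log units; within the scatter) in this same part of the molecule, offers the only guide. Going by these compounds, neither measured compound carries a methoxy group, so the swap itself remains untested. No step beyond the scatter is therefore expected, and the estimated step is a 1.0-fold lower number from compound 2 to compound 3 (0.02 log units; within the scatter) in this assay on this reading. For compound 3 the estimate is 33000 nM with 14000 nM to 70000 nM as the expected range.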

Compound 3, half-maximal inhibitory concentration: 44400 nM
The estimate for compound 3 lay 1.3-fold (0.13 log units) below the measured number; measured number inside the range.
By their numbers in this assay, from the lowest: compounds 2, 1 and 3 (each within the scatter of the next).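

In this assay, the change from 3-methylbenzyl to 4-methoxybenzyl (a 1.3-fold higher number from compound 2 to compound 3 (0.11 log units; within the scatter)) and the change from the 3,5-dimethylphenyl group to 4-methoxyphenyl (a 1.1-fold higher number from compound 1 to compound 3 (0.04 log units; within the scatter)) both stay within the scatter, so all three compounds cannot be told apart. The earlier pair differed only by a methyl group, whereas compound 3 brings a methoxy group with its hydrogen-bond acceptor onto the aromatic ring, and even this larger change on a saturated chain carbon bound to an amide-type nitrogen in a ring leaves the number unresolved from the others. No available evidence explains this flat reading.

Compound 3 alters both the group and its place on the aromatic ring, so the contribution of each remains unseparated. Going by these compounds, it also remains open whether an amine, a carboxylic acid or a longer chain at this position would shift the number beyond the scatter.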